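The source may hold more compounds than are shown below. What is called first, only, known or untested is meant among the compounds shown, and "the series" means these compounds.

Measured in an ADME assay on the whole organism (Mus musculus, strain Swiss Webster) for pharmacokinetics, read by LC-MS, at a dose of 50 mg/kg by the oral route; on this read-out lower numbers stand for lower exposure and higher numbers for higher exposure at the dose given:
- compound 1 `O=C(Nc1ccc(F)c(-c2nc3ncc(-c4ccc(F)cc4F)cc3[nH]2)c1)N1CCCC1`: 15600 ng.h/mL
- compound 2 `O=C(Nc1ccc(F)c(-c2nc3ncc(-c4ccc(F)cc4)cc3[nH]2)c1)N1CCCC1`: 10200 ng.h/mL

Compound 2 stands within the scatter of compound 1, so the two numbers give no order. Compound 3 `O=C(Nc1ccc(F)c(-c2nc3ncc(-c4ccc(O)cc4)cc3[nH]2)c1)N1CCCC1` differs from compound 2 by hydroxy in place of fluoro on an aromatic carbon. Within the data shown here, the only measured step that bears on this is a 1.5-fold lower number from compound 1 to compound 2 (0.18 log units; within the scatter). That step also removes a fluoro, but it brings in no hydroxy, so it is a weak guide. Among the measured compounds shown here, no measured compound carries a hydroxy. A lower number in this assay is expected, with low confidence, and the expected step is a 2.6-fold lower number from compound 2 to compound 3 (0.41 log units; beyond the scatter). For compound 3 the estimated value is 4000 ng.h/mL, with an expected range of 800 ng.h/mL to 15000 ng.h/mL.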

Compound 3, area under the concentration-time curve: 137 ng.h/mL
Compound 3: middle estimate off by 29-fold (1.47 log units), on the high side, outside the stated range (below it).
By their numbers in this assay, from the lowest: compound 3; then compounds 2 and 1 (each within the scatter of the next).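

In this assay, hydroxy in place of fluoro para to a large group gives a 74-fold lower number from compound 2 to compound 3 (1.87 log units; beyond the scatter), and 4-hydroxyphenyl in place of 2,4-difluorophenyl gives a 110-fold lower number from compound 1 to compound 3 (2.06 log units; beyond the scatter). Losing a fluoro at this group had stayed within the scatter, so this position is not indifferent to substitution: what enters matters here, not only which fluoro leaves. Nothing at hand bears on the cause of the drop. Going by these compounds, whether methoxy or an amine at the same place stays near compound 2 or drops as far as compound 3 remains open.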